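The compounds below may be only part of what the source reports. "The series", "measured", "known", "first", "only" and "open" are said of these compounds alone.

Of the compounds shown here, three sharing one core have been tested in a functional assay on A549 cells (Homo sapiens) for cytotoxicity, read by MTT assay, with a stated time of 72 h; on this read-out higher numbers stand for weaker inhibition and lower numbers for stronger inhibition. Compound 1 (`COc1ccc(/C=C2\CCC/C(=C\c3ccccc3Cl)C2=O)cc1OC`) gives > 20000 nM, which is a limit of the assay and not a number. Going by the values given here, compound 2 (`COc1ccc(/C=C2\CCC/C(=C\c3cccc(Br)c3)C2=O)cc1OC`) gives 12800 nM, the only true number so far. Compound 3 (`COc1ccc(/C=C2\CCC/C(=C\c3ccc(OC)c(OC)c3)C2=O)cc1`) gives > 20000 nM, again only a limit. Compound 4 (`COc1ccc(/C=C2\CCC/C(=C\c3cccc(Cl)c3Cl)C2=O)cc1OC`) carries 2,3-dichlorophenyl in place of 4-methoxyphenyl on a double-bonded chain carbon bound to a double-bonded ring carbon. Two measured changes at this same place bear on it: an at least 1.5-fold lower number from compound 1 to compound 2 (0.19 log units; that floor lies within the scatter) and an at least 1.5-fold higher number from compound 2 to compound 3 (0.19 log units; that floor lies within the scatter). Both are small, so only a small drop in this assay is expected, an estimated at least 1.3-fold lower number from compound 3 to compound 4 (0.12 log units; that floor lies within the scatter). For compound 4 the estimate is 15000 nM, with an expected range from 7000 nM to 30000 nM.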

Compound 4, half-maximal inhibitory concentration: > 20000 nM
Compound 4 ended at the assay's limit; the forecaster's own chance of this, stated with the estimate: 45%; middle value at least 1.3-fold (0.12 log units) away from the limit.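

Two chlorines at this place do no better than one: compound 4, with 2,3-dichlorophenyl, also gives only a limit of the assay, so its steps from compound 1 and compound 3 cannot be read. Going by these compounds alone, the one readable comparison, against 3-bromophenyl, is an at least 1.5-fold higher number from compound 2 to compound 4 (0.19 log units; that floor lies within the scatter). Compound 2 therefore remains the only true number in this assay, and the series mostly sits at one ceiling: the limit of > 20000 nM in this assay, at which 3 of the 4 values shown sit.

Still open, from the compounds shown here alone, is whether any group at this place can give a value clearly lower than that of compound 2. A phenyl ring carrying an amine or a carboxylic acid could test this.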